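Pyridin-3-yl for phenyl on the chain terminus

A few compounds are considered here, and "the series" means these few. Any claim that something is new, unique, unknown or untested is made for them only; others in the source may bear on it.

Measured so far:
compound 1, `N#C/N=C(/NCCCc1c[nH]cn1)NCCC(c1ccccc1)c1ccccc1`, < 5
compound 2, `N#C/N=C(/NCCCCc1c[nH]cn1)NCCCc1ccccc1`, 5.25

Compound 1 is reported in an in vitro functional assay on Sf9 cells for antagonist activity at histamine H2 receptor (Homo sapiens) (a higher number here means a more potent compound, by a factor of ten per unit of this negative logarithm, a lower number a less potent compound), only as a limit, < 5, and not as a number. Among the compounds with values here, compound 2 gives 5.25 in this assay and is therefore the only compound of the pair with a measured number. Compound 1 sits at the limit described as the limit of < 5 in this assay, at which 1 of the 2 values shown sits. Within the data shown here, no step between two measured compounds with a single structural difference is available, so no measured step size exists to lean on.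

Compound 3, `N#C/N=C(/NCCCCc1c[nH]cn1)NCCCc1cccnc1`, is not yet measured. It differs from compound 2 by pyridin-3-yl in place of phenyl on a saturated chain carbon, three bonds along the chain from an amine nitrogen. The shared core and the chain lengths are unchanged.

For compound 3 the expected step from compound 2 is a number 0.15 log units lower from compound 2 to compound 3 (within the scatter), which is not expected to exceed the usual scatter in either direction. Compound 3 is therefore estimated at 5.1 in this assay, within a range from 4.5 to 5.7.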

Compound 3, negative logarithm of the antagonist equilibrium constant: 5.92
Estimate against measurement, compound 3: 0.82 log units below; measured number outside the range, above it.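

In this assay, within the data shown here, the change at this position gives a number 0.67 log units higher from compound 2 to compound 3 (beyond the scatter), the first step with only one structural difference. The terminal ring is therefore not interchangeable here: the heavy-atom count stays the same, yet replacing phenyl with pyridin-3-yl, which adds one hydrogen-bond acceptor, changes the read-out beyond the scatter. No measured property shown bears on the reason for this step.

Going by these compounds, it remains open whether the gain depends on where the nitrogen sits in the ring, as pyridin-2-yl or pyridin-4-yl would show, or whether a second ring nitrogen, as in pyrimidin-5-yl, would extend it. Also open, on these data alone, is whether the step carries over to a longer chain between the ring and the amine nitrogen, since this single pair sets no pattern.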